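The compounds below may be only part of what the source reports. "The series", "measured", "known", "first", "only" and "open" are said of these compounds alone.

Compound 1 `COc1ccc2c(c1)C(C(C)c1ccccn1)=C(CCN(C)C)C2` gives 8910 nM in an assay on CHO-K1 cells for binding affinity to muscarinic acetylcholine receptor M5 (Homo sapiens); a higher number here means a weaker inhibitor, a lower number a stronger inhibitor. Compound 2 `Cc1ccc2c(c1)CC(CCN(C)C)=C2C(C)c1ccccn1` gives 1450 nM in this assay. Compound 3 `CC(C1=C(CCN2CCCC2)Cc2ccccc21)c1ccccn1` gives 2000 nM in this assay.

Compound 3 stands second highest of the three numbers. Its nearest neighbour is compound 2, whose number lies within the scatter of that of compound 3, while compound 1 sits beyond the scatter with the higher number. Compound 4 `CC(C1=C(CN(C)C(C)C)Cc2ccccc21)c1ccccn1` has not yet been measured. Against compound 3 the change is isopropyl(methyl)amino in place of (pyrrolidin-1-yl)methyl on a saturated chain carbon bound to a double-bonded ring carbon. Within the data shown here, no measured pair shows this change, so the data give no anchor for its direction. A step toward a somewhat higher number in this assay, of a size at the edge of the scatter, is expected from compound 3 to compound 4, a 1.8-fold higher number from compound 3 to compound 4 (0.24 log units; within the scatter). Compound 4 is estimated at 3500 nM, within a range from 1200 nM to 10000 nM.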

Compound 4, inhibition constant: 1120 nM
Compound 4: the middle estimate sits 3.1-fold (0.49 log units) above what was measured; the measured number lies below the stated range.
By their numbers in this assay, from the lowest: compounds 4, 2 and 3 (each within the scatter of the next); then compound 1.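

In this assay, replacing (pyrrolidin-1-yl)methyl with isopropyl(methyl)amino on the saturated chain carbon gives a 1.8-fold lower number from compound 3 to compound 4 (0.25 log units; within the scatter), and this step stays within the scatter. Among these compounds, this is the first direct comparison at this position, and it shows that the number holds when the ring gives way to an open-chain amine, a difference that also reads as 2-(pyrrolidin-1-yl)ethyl to (isopropyl(methyl)amino)methyl. Nothing available explains the step.

The compounds shown do not separate the loss of the ring from the change in the chain. They also leave open how a piperidine or morpholine would fare at this position.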